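Ethyl Versus Propyl Amine on a Shared Core

The source may hold more compounds than are shown below. What is called first, only, known or untested is meant among the compounds shown, and "the series" means these compounds.

Compound 1 `CC(=O)Nc1c(C)c(C)c2c(c1C)CC(C)(C)O2`: in a functional assay on the whole organism with Mus musculus as the target (on this read-out higher numbers stand for an effect only at larger amounts of compound and lower numbers for an effect already at smaller amounts), compound 1 gives > 100 mg/kg, a limit of the assay, not a number.
Compound 2 `CCC(=O)Nc1c(C)c(C)c2c(c1C)CC(C)(C)O2`: in this assay compound 2 gives > 100 mg/kg, again a limit of the assay.
Compound 3 `CCNc1c(C)c(C)c2c(c1C)CC(C)(C)O2`: in this assay compound 3 gives 38.9 mg/kg.

Two of three values sit at the limit of > 100 mg/kg in this assay, at which 2 of the 3 values shown sit. The change methyl in place of hydrogen on a saturated chain carbon bound to a carbonyl carbon gave a step that the two limits leave unreadable from compound 1 to compound 2. The two cores differ by ethyl in place of acetyl on a nitrogen on an aromatic ring, and this step gave an at least 2.5-fold lower number from compound 1 to compound 3 (0.41 log units; beyond the scatter). Compound 4 `CCCNc1c(C)c(C)c2c(c1C)CC(C)(C)O2` differs from compound 3 by methyl in place of hydrogen on a saturated chain carbon, two bonds along the chain from a nitrogen on an aromatic ring, the same kind of change as before, yet placed two bonds along the chain from a nitrogen on an aromatic ring instead of bound to a carbonyl carbon. Since the earlier step was unreadable, no guide exists, so a roughly unchanged result is expected, a 1.1-fold lower number from compound 3 to compound 4 (0.05 log units; within the scatter). Compound 4 is therefore estimated at 35 mg/kg, between 12 mg/kg and 100 mg/kg.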

Compound 4, dose for 50% inhibition: 51.1 mg/kg
Compound 4: middle estimate off by 1.5-fold (0.16 log units), on the low side; the range from low to high includes it.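

In this assay, going from ethylamino to propylamino gives a 1.3-fold higher number from compound 3 to compound 4 (0.12 log units; within the scatter), so this change makes no readable difference on this core. The same kind of change on the acetyl group, which turns compound 1 into compound 2, cannot be read, because both of those values are limits of the assay: the limit of > 100 mg/kg in this assay, at which 2 of the 4 values shown sit. Nothing here therefore shows whether the change carries from one core to the other, and the steps to propyl, an at least 1.9-fold lower number from compound 2 to compound 4 (0.29 log units; that floor lies within the scatter) and an at least 1.9-fold lower number from compound 1 to compound 4 (0.29 log units; that floor lies within the scatter), give only floors and not true sizes.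

On these data alone, it stays open whether a longer chain such as butyl would move the number. The same holds for a ring such as cyclopropyl, or for a free amine, on that nitrogen.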